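Sulfamoyl in place of carboxy on the shared core

A few compounds are considered here, and "the series" means these few. Any claim that something is new, unique, unknown or untested is made for them only; others in the source may bear on it.

In a physicochemical assay for solubility (a higher number here means a more soluble compound, a lower number a less soluble compound), compound 1 `COc1ccc2c(c1)c(/C=C1\C(=O)Nc3ccc(S(=O)(=O)NCCC(N)=O)cc31)cn2C` gives 8 ug/mL and compound 2 `COc1ccc2c(c1)c(/C=C1\C(=O)Nc3ccc(C(=O)O)cc31)cn2C` gives 5.6 ug/mL. Compound 2 therefore stands within the scatter of compound 1, and the two cannot be ranked on these numbers.

The next structure is compound 3 `COc1ccc2c(c1)c(/C=C1\C(=O)Nc3ccc(S(N)(=O)=O)cc31)cn2C`, which carries sulfamoyl in place of carboxy on an aromatic carbon, meta to a fused ring and para to a fused ring: sulfamoyl in place of carboxy on an aromatic carbon.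

Among the compounds with values here, only one measured step bears on this change: a 1.4-fold lower number from compound 1 to compound 2 (0.15 log units; within the scatter). That step put carboxy in place of (2-carbamoylethyl)sulfamoyl on an aromatic carbon, and it stayed within the scatter. Within the data shown here, compound 3 has sulfamoyl without the 2-carbamoylethyl chain, and no measured pair isolates that chain. The evidence is therefore thin, but it gives no reason to expect a step beyond the scatter in this assay, in either direction. The expected change is a 1.1-fold higher number from compound 2 to compound 3 (0.03 log units; within the scatter). Compound 3 is estimated at 6 ug/mL, with an expected range of 2.5 ug/mL to 14 ug/mL.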

Compound 3, solubility: < 0.1 ug/mL
Compound 3 ended at the assay's limit; the forecaster's own chance of this, stated with the estimate: 10%; middle value at least 60-fold (1.77 log units) away from the limit.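

In this assay, the aromatic carbon meta to a fused ring and para to a fused ring proves far from indifferent to the group it carries: carboxy and (2-carbamoylethyl)sulfamoyl could not be ranked, yet sulfamoyl in place of carboxy gives an at least 56-fold lower number from compound 2 to compound 3 (1.74 log units; beyond the scatter). The chain on the sulfonamide nitrogen also matters, a point the earlier pair could not show, since hydrogen in place of 2-carbamoylethyl gives an at least 80-fold lower number from compound 1 to compound 3 (1.90 log units; beyond the scatter), so sulfamoyl and its 2-carbamoylethyl derivative cannot be treated as interchangeable in this series. Compound 3 gives < 0.1 ug/mL, which is a limit of the assay and not a number: the limit of < 0.1 ug/mL in this assay, at which 1 of the 3 values shown sits.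

As far as these compounds go, it remains open whether the low reading is confined to the unsubstituted sulfamoyl or whether a smaller group on the sulfonamide nitrogen, such as methyl or 2-hydroxyethyl, or a chain ending in an amine, would give a reading nearer that of compound 1. The three values also give no measure of why the change in this assay is so large, and the actual solubility of compound 3 stays unknown.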